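Adding a phenyl next to the amine of compound 2

This account rests on a few compounds, and the source may have more. Where it says the series, first, only, none or still open, it means among the compounds named here.

Going by the values given here, compound 2 `NCC1CCN(c2ncnc3[nH]ccc23)CC1` gives 770 nM in an assay on isolated protein for inhibition of RAC-beta serine/threonine-protein kinase (Homo sapiens), read by radiometric assay and filter binding (a lower number here means a stronger inhibitor, a higher number a weaker inhibitor), the highest of the two numbers available; its only neighbour is compound 1 `NCC1(Cc2ccc(Cl)cc2)CCN(c2ncnc3[nH]ccc23)CC1`, which in this assay gives 5 nM. Among the compounds with values here, the one measured step, a 150-fold higher number from compound 1 to compound 2 (2.19 log units; beyond the scatter), shows that removing a 4-chlorobenzyl from a saturated ring carbon costs a great deal of potency. Compound 3 `NC(c1ccccc1)C1CCN(c2ncnc3[nH]ccc23)CC1` differs from compound 2 by phenyl in place of hydrogen on a saturated chain carbon bound to an amine nitrogen and a saturated ring carbon. Within the data shown here, no measured step places an aromatic ring at this chain carbon, so the bearing of a 150-fold higher number from compound 1 to compound 2 (2.19 log units; beyond the scatter) is indirect: it shows only that an aromatic group near the amine can lower the number strongly. Compound 3 is therefore expected to give a lower number than compound 2, with a step of an 11-fold lower number from compound 2 to compound 3 (1.04 log units; beyond the scatter) estimated, smaller than the measured one given the different place. Compound 3 is estimated at 70 nM, within 10 nM to 400 nM.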

Compound 3, half-maximal inhibitory concentration: 246 nM
Compound 3: the middle estimate sits 3.5-fold (0.55 log units) below what was measured; low and high end bracket the measured number.
By their numbers in this assay, from the lowest: compound 1; then compound 3; then compound 2.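

Phenyl in place of hydrogen on this chain carbon gives a 3.1-fold lower number from compound 2 to compound 3 (0.50 log units; beyond the scatter) in this assay and so shows that the position accepts an aromatic ring with a gain in potency. That step is much smaller than a 150-fold higher number from compound 1 to compound 2 (2.19 log units; beyond the scatter) in the same assay, although the two steps differ both in the place changed and in the group, so the large effect of the 4-chlorobenzyl on the saturated ring carbon does not carry over in full to a phenyl on the chain carbon. No measurement at hand explains the difference in size between these two steps.

The compounds shown leave open whether a 4-chlorophenyl or a benzyl on this chain carbon would lower the number further. They also leave open whether a small alkyl group such as methyl would give any gain there, or whether the gain needs an aromatic ring.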